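Thiazolyl to methylpyrimidinyl swap at the ether oxygen

The compounds below may be only part of what the source reports. "The series", "measured", "known", "first", "only" and "open" are said of these compounds alone.

Among the compounds with values here, compound 2 `COc1cccc(Oc2c(NS(=O)(=O)c3ccc(C(C)(C)C)cc3)ncnc2OCCOc2nccs2)c1` gives 12 nM in an assay on cells (Endothelial cell) for binding affinity to Endothelin-1 receptor (Sus scrofa) (on this read-out higher numbers stand for weaker inhibition and lower numbers for stronger inhibition), and stands highest of the two numbers so far; compound 1 `COc1cccc(Oc2c(NS(=O)(=O)c3ccc(C(C)(C)C)cc3)ncnc2OCCOc2ncccn2)c1` gives 1.9 nM in this assay. Within the data shown here, the one step to hand, a 6.3-fold higher number from compound 1 to compound 2 (0.80 log units; beyond the scatter), is the only measured change in this position. Compound 3 `COc1cccc(Oc2c(NS(=O)(=O)c3ccc(C(C)(C)C)cc3)ncnc2OCCOc2ncc(C)cn2)c1` carries 5-methylpyrimidin-2-yl in place of 1,3-thiazol-2-yl on an oxygen on a saturated carbon. This largely reverses the earlier step, so the expectation is a step of about a 4.8-fold lower number from compound 2 to compound 3 (0.68 log units; beyond the scatter), a lower number, beyond the scatter. Compound 3 is estimated at 2.5 nM, within 0.8 nM to 8 nM.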

Compound 3, half-maximal inhibitory concentration: 0.86 nM
Compound 3: the middle estimate sits 2.9-fold (0.46 log units) above what was measured; the range from low to high includes it.
By their numbers in this assay, from the lowest: compound 3; then compound 1; then compound 2.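

In this assay the methyl on the aromatic carbon of the pyrimidin-2-yl group is more than tolerated: the series shows a 2.2-fold lower number from compound 1 to compound 3 (0.34 log units; beyond the scatter) as a gain beyond the scatter. The swap from 1,3-thiazol-2-yl gives a 14-fold lower number from compound 2 to compound 3 (1.14 log units; beyond the scatter) and so recovers more than the thiazolyl group lost, which places 5-methylpyrimidin-2-yl lowest of the three. Nothing at hand explains this gain.

Open, as far as these compounds go, is whether an ethyl, a methoxy or an amine on that same ring carbon would hold or extend the gain. Also open, from the compounds shown here alone, is whether a methyl on the 1,3-thiazol-2-yl ring would give a comparable step.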